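This account rests on a few compounds, and the source may have more. Where it says the series, first, only, none or still open, it means among the compounds named here.

Compound 2, with the structure `NC1=NC2(CCOCC2)N(OCCCOc2ccc(Cl)cc2Cl)C(N)=N1`, is the starting point of this step. In an assay on isolated protein for inhibition of Dihydrofolate reductase (Homo sapiens), read by spectrophotometry, using NADPH, with stated times of 5 s and 6 min, tested at 5 uM (on this read-out higher numbers stand for a stronger effect at the one concentration tested and lower numbers for a weaker effect), compound 2 gives > 90%, which is a limit of the assay rather than a measured number. Its nearest measured neighbour is compound 1, with the structure `COc1ccc(OCCCON2C(N)=NC(N)=NC23CCOCC3)cc1`. In this assay compound 1 gives > 90%, again a limit and not a number. Among the compounds with values here, the one measured step, a step that the two limits leave unreadable from compound 1 to compound 2, therefore cannot be sized, since the limit of > 90% in this assay, at which 2 of the 2 values shown sit, covers both ends of it.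

The new compound, compound 3, has the structure `NC1=NC2(CCOCC2)N(OCCCOc2cccc(Br)c2)C(N)=N1`. It differs from compound 2 in one place: 3-bromophenyl in place of 2,4-dichlorophenyl on an oxygen on a saturated carbon.

Within the data shown here, the only step that bears on this change is the swap of one aryl group for another on the same oxygen, and that step left the read-out at the limit on both sides. On that basis compound 3 is expected to stay at or near the limit as well, with the estimated step that the limit leaves unreadable from compound 2 to compound 3 amounting to nothing beyond the scatter. The estimate for compound 3 in this assay is 93%, within a range from 84% to 99%.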

Compound 3, a percentage reported as inhibition, at one concentration (the size of the read-out at that concentration, not a potency): 86.7%
Estimate against measurement, compound 3: 6.3 percentage points above; the range from low to high includes it.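

In this assay compound 3 gives 86.7%, the only figure among the compounds shown that is a number and not a limit, so this position on an oxygen on a saturated carbon now has one reading that sits on the readable part of the scale. The change to 3-bromophenyl gives a number at least 3.3 percentage points lower from compound 2 to compound 3 (that floor lies within the scatter), and the same group gives a number at least 3.3 percentage points lower from compound 1 to compound 3 (that floor lies within the scatter), so neither step shows a loss that can be told apart from ordinary repeat variation, and the aryl group on this oxygen has now been swapped twice without a clear fall in the read-out. The true size of these steps stays unknown, and the step between the other two compounds cannot be read at all, because those two values are limits of the assay: the limit of > 90% in this assay, at which 2 of the 3 values shown sit.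

The compounds shown leave open what an amine or a carboxylic acid in place of the aryl group would do to the read-out, and what a longer chain would do. As far as these compounds go, a read-out at one concentration is not a potency, so how far these compounds stand apart in potency also remains open.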